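The compounds below may be only part of what the source reports. "The series", "measured", "known", "first", "only" and "open" are said of these compounds alone.

Measured in an ADME assay on 697 cells (Homo sapiens) for cytotoxicity, with a stated time of 48 h (a higher number here means a weaker inhibitor, a lower number a stronger inhibitor), where each entry is a limit and not a number:
Compound 1 `O=C(NO)c1cc(F)c(Cn2nnc(-c3ccco3)n2)c(F)c1`: > 1000 nM
Compound 2 `Nc1ccc(-c2nnn(Cc3c(F)cc(C(=O)NO)cc3F)n2)cc1`: > 1000 nM

In this assay compound 2 stands at > 1000 nM, which is a limit, so it has no exact place on the scale. The same holds across the small set: the limit of > 1000 nM in this assay, at which 2 of the 2 values shown sit. The next compound, compound 3 `O=C(NO)c1cc(F)c(Cn2nnc(-c3ccccn3)n2)c(F)c1`, carries pyridin-2-yl in place of 4-aminophenyl on an aromatic carbon. Within the data shown here, the one measured step that bears on this change swaps a group on that same carbon, and it is a step that the two limits leave unreadable from compound 1 to compound 2. It therefore offers no size to carry over, and no step beyond the scatter is expected. The expected step is a step that the limit leaves unreadable from compound 2 to compound 3. For compound 3 the estimated value is 2000 nM, with an expected range from 700 nM to 6000 nM, and another limit is the likeliest report.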

Compound 3, half-maximal inhibitory concentration: > 1000 nM
Compound 3 gave a limit, no number (the forecaster's own chance of this, stated with the estimate: 85%); the middle value is on the limit's open side.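

Among these compounds, compound 1, compound 2 and compound 3 are all reported only as limits, so no step among them can be read: the limit of > 1000 nM in this assay, at which 3 of the 3 values shown sit. As far as these compounds go, what stays open is the actual strength of each compound in this assay, and whether furan-2-yl, 4-aminophenyl and pyridin-2-yl differ there at all.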